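This account rests on a few compounds, and the source may have more. Where it says the series, first, only, none or still open, it means among the compounds named here.

Going by the values given here, in an ADME assay on BE(2)-C cells (Homo sapiens) for cytotoxicity, read by MTT assay, with a stated time of 20 h (a lower number here means that less compound is tolerated, a higher number that more compound is tolerated), compound 1 `O=C(c1cc2ccccc2n1Cc1ccc(Cl)cc1)N1CCC(C(=O)N2CCC[C@H]2CO)CC1` gives 98900 nM, the only actual number so far. Compound 2 `CN(Cc1ccccc1)C(=O)C1CCN(C(=O)c2cc3ccccc3n2Cc2ccc([N+](=O)[O-])cc2)CC1` reads > 100000 nM, which is a limit of the assay. Compound 3 `CN(Cc1ccccc1)C(=O)C1CCN(C(=O)c2cc3ccccc3n2Cc2ccc(C#N)cc2)CC1` reads > 100000 nM, also a limit and not a number. Compound 3 therefore has no exact position and stands at the limit of > 100000 nM in this assay, at which 2 of the 3 values shown sit. Among the compounds with values here, the single measured step is a step that the two limits leave unreadable from compound 2 to compound 3, with cyano in place of nitro on an aromatic carbon. It gives no size to carry forward, and it concerns a different place in the structure.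

The change to compound 4 `CC(=O)n1c(C(=O)N2CCC(C(=O)N(C)Cc3ccccc3)CC2)cc2ccccc21` is acetyl in place of 4-cyanobenzyl on an aromatic nitrogen. Within the data shown here, no measured step covers this replacement, so no direction can be drawn from the data and no step beyond the scatter is expected in this assay. The estimate means an expected a number no higher from compound 3 to compound 4 (the limit leaves the size open). For compound 4 the expected value is 100000 nM, with an estimated range of 40000 nM to 200000 nM.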

Compound 4, half-maximal cytotoxic concentration: > 50000 nM
Compound 4 gave a limit, no number (the forecaster's own chance of this, stated with the estimate: 60%); the middle value does not contradict the limit.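

Compound 4 reads > 50000 nM in this assay, a limit and not a number. Compound 2 and compound 3 also stand at limits, so neither step to compound 4 can be read. The compounds shown leave open how acetyl compares with 4-cyanobenzyl or 4-nitrobenzyl on the aromatic nitrogen.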